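The source may report more compounds than this note shows. Statements on the series, on what has been measured and on what is new or still open speak of the compounds shown alone.

Compound 1 `CC(=O)N[C@@H]1CCC[C@H](C(=O)Nc2cc(-c3cnn4c3CCCC4)c(Cl)cn2)C1` gives 310000 nM in a physicochemical assay for solubility, in phosphate buffer, at pH 7.4; on this read-out lower numbers stand for lower solubility and higher numbers for higher solubility.
Compound 2 `CC(=O)N[C@@H]1CCC[C@H](C(=O)Nc2cc(-c3cnc(C)n3C)c(Cl)cn2)C1` reaches the limit of this assay, reported as > 1000000 nM, and so yields no number.

On the numbers shown, compound 1 stands as the only measured value; the other result is a limit. Among the compounds with values here, the single measured step, an at least 3.2-fold higher number from compound 1 to compound 2 (0.50 log units; beyond the scatter), runs up to the limit (the limit of > 1000000 nM in this assay, at which 1 of the 2 values shown sits), so its true size is not known beyond the floor given.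

Compound 3 `CC(=O)N[C@@H]1CCC[C@H](C(=O)Nc2cc(-c3cnn4c3CCC4)c(Cl)cn2)C1` differs from compound 1 by a group of 8 heavy atoms (6 carbon, 2 nitrogen; one five-membered non-aromatic ring with 1 hetero atom, one five-membered aromatic ring with 2 hetero atoms) in place of a group of 9 heavy atoms (7 carbon, 2 nitrogen; one five-membered aromatic ring with 2 hetero atoms, one six-membered non-aromatic ring with 1 hetero atom), on an aromatic carbon. Within the data shown here, only the step from compound 1 to compound 2 bears on this change: there too a smaller group replaced the nine-heavy-atom group on the same aromatic carbon, and the number in this assay went up. Here the change is smaller, as a five-membered non-aromatic ring remains in place of the six-membered one, so a modest rise is expected, a 1.5-fold higher number from compound 1 to compound 3 (0.16 log units; within the scatter), possibly within the scatter. Compound 3 is estimated at 450000 nM, with a range of 250000 nM to 900000 nM.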

Compound 3, solubility: 160000 nM
Compound 3: middle estimate off by 2.8-fold (0.45 log units), on the high side; the whole stated range lies above it.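

In this assay, the change from the group with the six-membered non-aromatic ring to the group with the five-membered non-aromatic ring gives a 1.9-fold lower number from compound 1 to compound 3 (0.29 log units; within the scatter), so the size of that ring does not separate these two compounds at this position, opposite the ring nitrogen. The group with a single five-membered aromatic ring is now set apart from both compounds that carry a second, non-aromatic ring, with an at least 6.2-fold lower number from compound 2 to compound 3 (0.79 log units; beyond the scatter). Compound 2 gives only a limit, > 1000000 nM, so this step is a floor and its true size stays unknown: the limit of > 1000000 nM in this assay, at which 1 of the 3 values shown sits.

Whether the second ring as such accounts for this gap stays open, since the groups also differ in other atoms. As far as these compounds go, how an amine or a carboxylic acid on the non-aromatic ring would read in this assay also stays open.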